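Ring-closure of the chain amine in a benzoxazole series

The source may hold more compounds than are shown below. What is called first, only, known or untested is meant among the compounds shown, and "the series" means these compounds.

Measured so far:
compound 1 `CC(C)(C)c1ccc(Oc2ccc3nc(-c4ccc(OCCCN5CCCCC5)cc4)oc3c2)cc1` — "not active" (no number reported)
compound 2 `CCN(CC)CCCOc1ccc(-c2nc3ccc(Oc4ccc(C(F)(F)F)cc4)cc3o2)cc1` — 34.9%

Among the compounds with values here, in an assay on isolated protein for inhibition of advanced glycosylation end product-specific receptor (Homo sapiens), read by FRET, with stated times of 30 min and 1 h, tested at 4 uM (a higher number here means more inhibition at the concentration tested (going by the name of the read-out), a lower number less inhibition), compound 2 gives 34.9%, the only number reported; compound 1 carries no number at all. Compound 3 `FC(F)(F)c1ccc(Oc2ccc3nc(-c4ccc(OCCCN5CCCCC5)cc4)oc3c2)cc1` differs from compound 2 in one place: piperidin-1-yl in place of diethylamino on a saturated chain carbon, three bonds along the chain from an oxygen on an aromatic ring. Within the data shown here, no pair of measured compounds shows this change, so its size is unknown. Since compound 2 gives 34.9% and the change keeps one hydrogen-bond acceptor and no charge, the step is expected to be small, within the scatter. Compound 3 is therefore estimated at 35% (range 15% to 55%), a step of a number 0.1 percentage points higher from compound 2 to compound 3 (within the scatter).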

Compound 3, a percentage reported as inhibition, at one concentration (the size of the read-out at that concentration, not a potency): 44.3%
Compound 3: middle estimate off by 9.3 percentage points, on the low side; measured number inside the range.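

In this assay, replacing diethylamino with piperidin-1-yl on this saturated chain carbon gives a number 9.4 percentage points higher from compound 2 to compound 3 (within the scatter) and so shows that closing the amine into a ring at this position causes no change beyond the scatter. No available measurement offers an explanation for this step.

From the compounds shown here alone, whether morpholin-4-yl, pyrrolidin-1-yl or a longer chain would read the same here remains open. Also open, going by these compounds, is how the piperidin-1-yl chain fares with other groups on the shared core, since compound 1 carries 3-(piperidin-1-yl)propyl and gives "not active" (no number reported) with no number to compare.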